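This account rests on a few compounds, and the source may have more. Where it says the series, first, only, none or still open, it means among the compounds named here.

In a toxicity assay on GES1 cells (Homo sapiens) for inhibition, read by MTT assay, with a stated time of 72 h (on this read-out higher numbers stand for weaker inhibition and lower numbers for stronger inhibition), the three measured compounds are compound 1 `Cc1cc(N2CC[C@@H](C)[C@@H](N(C)c3ncnc4[nH]ccc34)C2)n2ncnc2n1` with 57900 nM, compound 2 `CCCSc1nc2nc(C)cc(N3CC[C@@H](C)[C@@H](N(C)c4ncnc5[nH]ccc45)C3)n2n1` with 67100 nM, and compound 3 `Cc1cc(N2CC[C@@H](C)[C@@H](N(C)c3ncnc4[nH]ccc34)C2)n2nc(SCc3ccc(C(F)(F)F)cc3)nc2n1` with 17300 nM. Compound 3 holds the lowest number of the three, and its nearest neighbour is compound 1, since a 3.3-fold lower number from compound 1 to compound 3 (0.52 log units; beyond the scatter), while the gap to compound 2 is wider, since a 3.9-fold lower number from compound 2 to compound 3 (0.59 log units; beyond the scatter). The step from compound 1 to compound 2 is a different matter, as a 1.2-fold higher number from compound 1 to compound 2 (0.06 log units; within the scatter).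

Compound 4 `Cc1cc(N2CC[C@@H](C)[C@@H](N(C)c3ncnc4[nH]ccc34)C2)n2nc(SCc3csc4ccc(Cl)cc34)nc2n1` has not yet been measured in this assay. Its difference from compound 3 is 5-chloro-1-benzothiophen-3-yl in place of 4-(trifluoromethyl)phenyl on a saturated chain carbon bound to a sulfur.

Among the measured compounds shown here, the step that bears most on this change is the one from compound 2 to compound 3, where a 4-(trifluoromethyl)phenyl entered for an ethyl on the same saturated chain carbon bound to a sulfur. Here one aromatic system of comparable size replaces another, so the author expects a step from compound 3 to compound 4 in this assay of about a 1.2-fold lower number from compound 3 to compound 4 (0.06 log units; within the scatter), that is, none beyond the scatter. The estimate for compound 4 in this assay is therefore 15000 nM, with a range from 6000 nM to 40000 nM.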

Compound 4, half-maximal inhibitory concentration: > 100000 nM
Compound 4: no number, only a limit (the forecaster's own chance of this, stated with the estimate: 5%); at least 6.6-fold (0.82 log units) between middle value and limit.
By their numbers in this assay, from the lowest: compound 3; then compounds 1 and 2 (each within the scatter of the next). At a limit, above all of these: compound 4.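

In this assay compound 4 gives a limit and not a number: the limit of > 100000 nM in this assay, at which 1 of the 4 values shown sits. On the saturated chain carbon bound to a sulfur, two aromatic groups of 10 heavy atoms each do not behave alike, as 5-chloro-1-benzothiophen-3-yl in place of 4-(trifluoromethyl)phenyl gives an at least 5.7-fold higher number from compound 3 to compound 4 (0.76 log units; beyond the scatter), so the lower number of compound 3 cannot be credited to just any aromatic group at this place. The other two steps, an at least 1.4-fold higher number from compound 2 to compound 4 (0.17 log units; that floor lies within the scatter) and an at least 1.7-fold higher number from compound 1 to compound 4 (0.23 log units; that floor lies within the scatter), offer only floors, so these comparisons do not show a real gap.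

The compounds shown leave open how far compound 4 lies beyond its limit. They also leave open whether the chlorine or the fused ring carries the change, which a plain 1-benzothiophen-3-yl or a 4-chlorophenyl at this place could separate.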